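Cyclohexyl replaces the aryl group: expected cytotoxicity of compound 4

The compounds below may be only part of what the source reports. "The series", "measured", "known", "first", "only" and "open" are said of these compounds alone.

Compound 1 `O=C(NC(=S)N1CCc2c(OCCCCCOc3ccc(Cl)cc3)cccc21)c1ccc([N+](=O)[O-])cc1`, compound 2 `O=C(NC(=S)N1CCc2c(OCCCCCOc3ccc(Cl)cc3)cccc21)c1ccc(F)cc1` and compound 3 `CN(C)c1ccc(C(=O)NC(=S)N2CCc3c(OCCCCCOc4ccc(Cl)cc4)cccc32)cc1` share one core and differ only in the substituent on the aromatic ring attached to the carbonyl carbon. In an ADME assay on Huh-7 cells (Homo sapiens) for cytotoxicity (on this read-out lower numbers stand for higher toxicity in this test and higher numbers for lower toxicity in this test), compound 1 gives 13600 nM and compound 2 gives 31100 nM. Compound 3 is recorded only as a limit, > 50000 nM, namely (the limit of > 50000 nM in this assay, at which 1 of the 3 values shown sits). The measured steps, a 2.3-fold higher number from compound 1 to compound 2 (0.36 log units; beyond the scatter), an at least 3.6-fold higher number from compound 1 to compound 3 (0.56 log units; beyond the scatter) and an at least 1.6-fold higher number from compound 2 to compound 3 (0.20 log units; that floor lies within the scatter), all concern substituent swaps on that aromatic ring. Compound 4 `O=C(NC(=S)N1CCc2c(OCCCCCOc3ccc(Cl)cc3)cccc21)C1CCCCC1` instead carries cyclohexyl in place of 4-(dimethylamino)phenyl on a carbonyl carbon. Among the measured compounds shown here, no measured step covers such a change, so none gives a direction, and compound 3 already sits at the limit. Compound 4 is therefore expected near 40000 nM, within 15000 nM to 100000 nM. That expected step reads an at least 1.2-fold lower number from compound 3 to compound 4 (0.09 log units; that floor lies within the scatter).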

Compound 4, half-maximal cytotoxic concentration: > 50000 nM
Compound 4 gave a limit, no number; the forecaster's own chance of this, stated with the estimate: 45%; at least 1.2-fold (0.09 log units) between middle value and limit.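

In this assay compound 4 is recorded only as a limit (> 50000 nM), so an aromatic ring on this carbonyl carbon is not required for a read-out at that limit. Cyclohexyl in place of the substituted aryl groups gives an at least 3.6-fold higher number from compound 1 to compound 4 (0.56 log units; beyond the scatter) and an at least 1.6-fold higher number from compound 2 to compound 4 (0.20 log units; that floor lies within the scatter) in the same assay. The step from 4-(dimethylamino)phenyl to cyclohexyl cannot be read because compound 3 and compound 4 both stand at a limit: the limit of > 50000 nM in this assay, at which 2 of the 4 values shown sit.

Where either compound truly lies beyond that limit stays open. So does whether a tert-butyl group, a longer alkyl chain or an amine on this carbonyl carbon would also reach it.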